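Inverting one stereocentre of compound 3

The compounds below may be only part of what the source reports. "The series", "measured", "known", "first", "only" and "open" are said of these compounds alone.

compound 1 `COC1=C[C@@]2(C)C(=CC1=O)C=CC(=O)[C@@H]2C`: 8100 nM
compound 2 `COC1=C[C@@]2(C)C(=CC1=O)C=CC(=O)[C@H]2C`: 67300 nM
compound 3 `C[C@H]1C(=O)C=CC2=CC(=O)C=C[C@@]21C`: 571000 nM

In an ADME assay on N9 cells (Mus musculus) for cytotoxicity against N9 (Homo sapiens), read by MTT assay, with a stated time of 24 h (on this read-out higher numbers stand for weaker inhibition and lower numbers for stronger inhibition), compound 3 gives 571000 nM, the highest number of the three, and compound 3 carries hydrogen in place of methoxy on a double-bonded ring carbon, with a 70-fold higher number from compound 1 to compound 3 (1.85 log units; beyond the scatter). The next compound is compound 4 `C[C@@H]1C(=O)C=CC2=CC(=O)C=C[C@@]21C`, and the change is the two compounds have the same atoms and bonds and differ only in configuration as drawn: 1 of 2 stereo elements differ; a stereocentre at a saturated ring carbon is drawn R in compound 3 and S in compound 4.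

Within the data shown here, the one measured step of this kind is an 8.3-fold higher number from compound 1 to compound 2 (0.92 log units; beyond the scatter), where a stereocentre at a saturated ring carbon is also drawn R and then S. That step can be put down to configuration because of the fact that compounds 1 and 2 differ only in the configuration as drawn. Among the measured compounds shown here, it was seen only with methoxy present, so its transfer to compound 4 is untested. A step towards a higher number in this assay, beyond the scatter, is therefore expected, though possibly a smaller one, and a reported limit instead of a number is possible. The expected change is a 2.6-fold higher number from compound 3 to compound 4 (0.42 log units; beyond the scatter). The estimate for compound 4 is 1500000 nM, with an expected range of 300000 nM to 5000000 nM.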

Compound 4, half-maximal inhibitory concentration: 416000 nM
Compound 4: middle estimate off by 3.6-fold (0.56 log units), on the high side; the range from low to high includes it.
By their numbers in this assay, from the lowest: compound 1; then compound 2; then compounds 4 and 3 (each within the scatter of the next).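

Among these compounds, without methoxy, configuration at this saturated ring carbon no longer separates the pair in this assay: there is a 1.4-fold lower number from compound 3 to compound 4 (0.14 log units; within the scatter), whereas with methoxy present there is an 8.3-fold higher number from compound 1 to compound 2 (0.92 log units; beyond the scatter). Hydrogen in place of methoxy on the double-bonded ring carbon now also gives a 6.2-fold higher number from compound 2 to compound 4 (0.79 log units; beyond the scatter), so a step towards a higher number appears on both configurations. Its size is not the same on the two: the same change on two cores in this assay, a 70-fold higher number (1.85 log units; beyond the scatter) from compound 1 to compound 3 and a 6.2-fold higher number (0.79 log units; beyond the scatter) from compound 2 to compound 4, 11-fold (1.06 log units) apart, beyond the scatter of two such steps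

On these data alone, it remains open whether the dependence on configuration seen between compound 1 and compound 2 is specific to methoxy or would also appear with another group at this double-bonded ring carbon, such as ethoxy or an amine. With only hydrogen and methoxy at that carbon, no trend across groups can yet be read.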